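Replacing a benzyl with a carbonyl link on an indole nitrogen

This account rests on a few compounds, and the source may have more. Where it says the series, first, only, none or still open, it means among the compounds named here.

Measured so far:
compound 1, `CC(C)c1onc(-c2c(Cl)cccc2Cl)c1COc1ccc2cc(-c3ccc(C(=O)O)cc3)sc2c1`, 220 nM in an assay on CV-1 cells with Bile acid receptor (Homo sapiens) as the target, read by a luciferase reporter; on this read-out lower numbers stand for an effect already at smaller amounts and higher numbers for an effect only at larger amounts of compound
compound 2, `CC(C)c1onc(-c2c(Cl)cccc2Cl)c1COc1ccc2c(ccn2Cc2cccc(C(=O)O)c2)c1`, 210 nM in this assay

Compound 1 and compound 2 share a core and differ in how the acid-bearing ring is attached. In this assay compound 2 gives 210 nM and compound 1 gives 220 nM; the two numbers lie within the usual scatter of each other, so no order between them can be read.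

Compound 3, `CC(C)c1onc(-c2c(Cl)cccc2Cl)c1COc1ccc2c(ccn2C(=O)c2cccc(C(=O)O)c2)c1`, has not yet been measured. It differs from compound 2 in one place: (3-carboxyphenyl)carbonyl in place of 3-carboxybenzyl on an aromatic nitrogen. The acid still sits on the same ring, but the link to the aromatic nitrogen now carries a carbonyl. For the measured compounds named here, no measured pair shows such a change, so the size of the step is open. A modest rise in the number, on the edge of the scatter, is expected for compound 3, with a 2.4-fold higher number from compound 2 to compound 3 (0.38 log units; beyond the scatter). The estimate for compound 3 is 500 nM, in a range from 150 nM to 2000 nM.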

Compound 3, half-maximal effective concentration: 860 nM
Compound 3: middle estimate off by 1.7-fold (0.24 log units), on the low side, and the stated range covers the measured number.
By their numbers in this assay, from the lowest: compounds 2 and 1 (each within the scatter of the next); then compound 3.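

Changing 3-carboxybenzyl to (3-carboxyphenyl)carbonyl on the aromatic nitrogen gives a 4.1-fold higher number from compound 2 to compound 3 (0.61 log units; beyond the scatter) in this assay. This shows that the link at this position matters: the acid-bearing ring stays, yet with the carbonyl in the link, a larger amount of compound is needed for the effect. Nothing available explains why the number rises with this change.

On these data alone, with only these two links on the aromatic nitrogen, it remains open how a sulfonyl link or a longer chain would compare with them. As far as these compounds go, it is also open whether the carbonyl link would give a step of similar size if a tetrazole replaced the carboxylic acid.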